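Chlorine-bearing four-membered ring replaces indanyl on the propyl chain

The compounds below may be only part of what the source reports. "The series", "measured", "known", "first", "only" and "open" are said of these compounds alone.

Measured compounds:
Compound 1, `c1ccc2c(c1)CC2CCCN1CCN(c2cccc3c2OCCO3)CC1`, 0.45 mg/kg
Compound 2, `c1ccc2c(c1)CCC2CCCN1CCN(c2cccc3c2OCCO3)CC1`, 0.23 mg/kg
Compound 3, `Clc1cccc2c1CC2CCN1CCN(c2cccc3c2OCCO3)CC1`, 20 mg/kg

In an assay for activation of Adrenergic receptor alpha-1 (Rattus norvegicus) (on this read-out lower numbers stand for an effect already at smaller amounts and higher numbers for an effect only at larger amounts of compound), compound 2 gives 0.23 mg/kg, the smallest number among the three; compound 1 sits close to it, the step of a 2.0-fold lower number from compound 1 to compound 2 (0.29 log units; within the scatter) lying within the scatter, while compound 3 stands far away. The unmeasured compound 4, `Clc1cccc2c1CC2CCCN1CCN(c2cccc3c2OCCO3)CC1`, differs from compound 2 by a group of 9 heavy atoms (8 carbon, 1 chlorine; one four-membered non-aromatic ring of carbon only, one six-membered aromatic ring of carbon only) in place of a group of 9 heavy atoms (9 carbon; one five-membered non-aromatic ring of carbon only, one six-membered aromatic ring of carbon only), on a saturated chain carbon, three bonds along the chain from an amine nitrogen in a ring.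

Among the compounds with values here, two measured steps bear on this change. The ring-size change alone, a 2.0-fold lower number from compound 1 to compound 2 (0.29 log units; within the scatter), did not move the number beyond the scatter. The introduction of chlorine onto the four-membered ring system, together with a shorter chain, gave a 44-fold higher number from compound 1 to compound 3 (1.65 log units; beyond the scatter), a large shift towards higher numbers. Compound 4 carries the chlorine but keeps the three-bond chain of compound 2, so a step of roughly that kind, though possibly somewhat smaller, is expected: a 35-fold higher number from compound 2 to compound 4 (1.54 log units; beyond the scatter). Compound 4 is therefore estimated at 8 mg/kg in this assay, with a range from 1.5 mg/kg to 40 mg/kg.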

Compound 4, dose for half-maximal effect: 1.25 mg/kg
Compound 4: middle estimate off by 6.4-fold (0.81 log units), on the high side; the whole stated range lies above it.
By their numbers in this assay, from the lowest: compounds 2 and 1 (each within the scatter of the next); then compound 4; then compound 3.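

In this assay, within the data shown here, chloro in place of hydrogen on an aromatic carbon, with the three-bond chain kept, gives a 2.8-fold higher number from compound 1 to compound 4 (0.44 log units; beyond the scatter), a modest step that isolates the chlorine for the first time. The large step of a 44-fold higher number from compound 1 to compound 3 (1.65 log units; beyond the scatter) therefore cannot be credited to the chlorine alone: compound 3, with its two-bond chain, gives 20 mg/kg, whereas compound 4 gives 1.25 mg/kg. Replacing 2,3-dihydro-1H-inden-1-yl with the chlorine-bearing group, which changes both ring size and substituent, also stays modest at a 5.4-fold higher number from compound 2 to compound 4 (0.74 log units; beyond the scatter). Nothing shown here gives a reason for these shifts. Still open, from the compounds shown here alone, is whether fluoro or methoxy on the same aromatic carbon would match chloro, and whether chloro on the 2,3-dihydro-1H-inden-1-yl group would give a similar step. A longer chain, such as butyl, also remains untested among the compounds shown.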